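Chain extension on the weakest member of the series

The source may report more compounds than this note shows. Statements on the series, on what has been measured and on what is new or still open speak of the compounds shown alone.

Three compounds have numbers in a functional assay (aorta) with Oryctolagus cuniculus as the target; on this read-out higher numbers stand for weaker inhibition and lower numbers for stronger inhibition. Compound 1 `OCc1ccc(-c2nn(Cc3ccc(Cl)s3)c3ccccc23)o1` gives 7200 nM in this assay. Compound 2 `CCc1c[nH]c(-c2nn(Cc3ccccc3F)c3ncccc23)n1` gives 600 nM in this assay, the lowest number of the three. Compound 3 `CCc1cnc(-c2nn(Cc3ccccc3F)c3ncccc23)nc1N` gives 272000 nM in this assay, the highest number of the three, with its gaps to both compound 1 and compound 2 well beyond the scatter, so it is the weakest inhibitor of the set. No pair among these three differs in only one place, so no single-change step is known.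

Compound 4 `CC(C#N)CCCCCc1cnc(-c2nn(Cc3ccccc3F)c3ncccc23)nc1N` is the next structure to be measured in this assay. It differs from compound 3 by one change: 4-cyanopentyl in place of hydrogen on a saturated chain carbon, two bonds along the chain from an aromatic carbon. For the measured compounds named here, no measured pair in this assay shows what such a chain extension does, so the direction of the step is not known from the data. With that in mind, a step of modest size is expected, most likely toward a lower number, and possibly no step beyond the scatter: from compound 3 to compound 4 the expected change is a 1.8-fold lower number from compound 3 to compound 4 (0.26 log units; within the scatter). Compound 4 is therefore estimated at 150000 nM in this assay, with a range from 30000 nM to 800000 nM, and there is a real chance that the assay reports only a limit.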

Compound 4, half-maximal inhibitory concentration: 1290000 nM
Beside the measured number, compound 4's estimate is 8.6-fold (0.93 log units) below it, outside the stated range (above it).
By their numbers in this assay, from the lowest: compound 2; then compound 1; then compound 3; then compound 4.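

Working notes on the chain at this position: in this assay, 4-cyanopentyl in place of hydrogen on a saturated chain carbon, two bonds along the chain from an aromatic carbon, gives a 4.7-fold higher number from compound 3 to compound 4 (0.68 log units; beyond the scatter). For the compounds shown here, this is the first single-change step, and it shows that this position is not silent: the change moves the number beyond the scatter, and it moves it towards weaker inhibition, so adding this chain of 7 heavy atoms brings no gain here. No measurement at hand bears on why the number moves in this direction.

Going by these compounds alone, the single step cannot separate the contribution of the chain from that of the nitrile, so a plain pentyl chain, a shorter chain such as ethyl or propyl, and a longer chain all remain open, as does the question of whether the number rises steadily with chain length. Also open, going by these compounds, is whether another group in place of the nitrile, such as a carboxylic acid or an amine, would reverse the direction of the step or leave it unchanged.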